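Cyclopropyl for propargyl on the amide nitrogen

The compounds below may be only part of what the source reports. "The series", "measured", "known", "first", "only" and "open" are said of these compounds alone.

Of the compounds shown here, three have been measured so far in a functional assay on the whole organism (strain Icem-CET (SPF Caw)) for inhibition, with Mus musculus as the target, with a stated time of 30 min; on this read-out higher numbers stand for an effect only at larger amounts of compound and lower numbers for an effect already at smaller amounts. Within the data shown here, compound 1 `C/C(C(=O)NC1CC1)=C(/C)c1ccc(Br)cc1` gives 8.2 mg/kg, and compound 2 `C/C(C(=O)NC1CC1)=C(/C)c1ccc(F)cc1` gives 25 mg/kg; the single one-place step between them, a 3.0-fold higher number from compound 1 to compound 2 (0.48 log units; beyond the scatter), is a halogen swap on the aromatic ring. Compound 3 `C#CCNC(=O)/C(C)=C(\C)c1ccccc1` gives 45.3 mg/kg, the highest of the three numbers; against compound 2 it sits within the scatter, against compound 1 it lies beyond it.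

Compound 4 `C/C(C(=O)NC1CC1)=C(/C)c1ccccc1` differs from compound 3 by cyclopropyl in place of propargyl on an amide-type nitrogen. Among the measured compounds shown here, no measured step bears on this change: the only step in hand concerns the aromatic halogen, not the amide substituent. What can be said is that compound 1 and compound 2 also carry cyclopropyl on the amide nitrogen and give the lower numbers in this assay, while compound 3 is the only propargyl case.

For the measured compounds named here, with no direct precedent, compound 4 is expected to fall near compound 3, the step of a 1.5-fold lower number from compound 3 to compound 4 (0.18 log units; within the scatter) estimated as a shift not clearly beyond the scatter. The estimate for compound 4 is 30 mg/kg, with a range from 12 mg/kg to 75 mg/kg.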

Compound 4, dose for half-maximal effect: 55.9 mg/kg
Estimate against measurement, compound 4: 1.9-fold (0.27 log units) below; measured number inside the range.
By their numbers in this assay, from the lowest: compound 1; then compounds 2, 3 and 4 (each within the scatter of the next, the first and the last beyond it).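

In this assay, cyclopropyl in place of propargyl on the amide-type nitrogen gives a 1.2-fold higher number from compound 3 to compound 4 (0.09 log units; within the scatter), so with hydrogen on the aromatic carbon this step does not separate the two groups. Compound 4 also gives the halogens a hydrogen reference with cyclopropyl held constant: a 2.2-fold higher number from compound 2 to compound 4 (0.35 log units; beyond the scatter) and a 6.8-fold higher number from compound 1 to compound 4 (0.83 log units; beyond the scatter), both beyond the scatter, so the lower numbers of compound 1 and compound 2 go with the halogen and not with cyclopropyl alone. Nothing available gives a reason for any of these steps.

Open, as far as these compounds go, is whether propargyl and cyclopropyl also remain within the scatter of each other when bromo sits on the aromatic ring. Also open, from the compounds shown here alone, is how chloro or methoxy on that ring would read, or a longer chain such as butyl on the amide nitrogen.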